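Opening the cyclic urea: what to expect for compound 4

A few compounds are considered here, and "the series" means these few. Any claim that something is new, unique, unknown or untested is made for them only; others in the source may bear on it.

Compound 1 `Cc1ccc2c(C3CCN(CCN4CCN(C(C)C)C4=O)CC3)cn(-c3ccc(F)cc3)c2c1` gives the lowest number of the three measured compounds in an assay on cell membranes for displacement of a labelled ligand from Adrenergic receptor alpha-1 (Rattus norvegicus) (a higher number here means a weaker inhibitor, a lower number a stronger inhibitor), at 85 nM. Its nearest neighbour is compound 3 `Cc1ccc2c(C3CCN(CCN4CCN(C(C)C)C4=O)CC3)cn(-c3cccc(F)c3)c2c1`, which gives 670 nM in this assay, and the furthest is compound 2 `CC(C)c1ccc2c(C3CCN(CCN4CCN(C(C)C)C4=O)CC3)cn(-c3ccc(F)cc3)c2c1`, which gives 730 nM. Both measured steps move away from compound 1 by similar margins: an 8.6-fold higher number from compound 1 to compound 2 (0.93 log units; beyond the scatter), and a 7.9-fold higher number from compound 1 to compound 3 (0.90 log units; beyond the scatter). Compound 4 `Cc1ccc2c(C3CCN(CCNC(=O)NC(C)C)CC3)cn(-c3ccc(F)cc3)c2c1` has not yet been measured; it differs from compound 1 by (isopropylcarbamoyl)amino in place of 3-isopropyl-2-oxoimidazolidin-1-yl on a saturated chain carbon, two bonds along the chain from an amine nitrogen in a ring. Neither measured step touches this part of the molecule: one alters the group on the aromatic carbon, the other the fluorophenyl on the aromatic nitrogen, and each weakened binding by a modest, comparable amount. Within the data shown here, there is thus no direct precedent for the change in compound 4, and the expectation can only lean on the fact that every departure from compound 1 so far, seen in an 8.6-fold higher number from compound 1 to compound 2 (0.93 log units; beyond the scatter) and a 7.9-fold higher number from compound 1 to compound 3 (0.90 log units; beyond the scatter), has cost potency. A modest loss is expected, a 2.6-fold higher number from compound 1 to compound 4 (0.41 log units; beyond the scatter). Compound 4 is estimated at 220 nM, within a range of 60 nM to 800 nM.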

Compound 4, half-maximal inhibitory concentration: 76 nM
Compound 4: the middle estimate sits 2.9-fold (0.46 log units) above what was measured; measured number inside the range.
By their numbers in this assay, from the lowest: compounds 4 and 1 (each within the scatter of the next); then compounds 3 and 2 (each within the scatter of the next).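

In this assay the exchange of the ring-closed 3-isopropyl-2-oxoimidazolidin-1-yl for the open (isopropylcarbamoyl)amino gives a 1.1-fold lower number from compound 1 to compound 4 (0.05 log units; within the scatter) and so, unlike the two earlier changes on the shared core, stays within the scatter. The five-membered ring is thus not needed at this position to hold the number at the level of compound 1, even though the open group has fewer heavy atoms and carries 2 hydrogen-bond donors where the ring carries 0. Nothing measured here accounts for this tolerance.

The compounds shown leave open whether a plain amine or a simple amide would serve as well as the (isopropylcarbamoyl)amino group at this position. They also leave open whether a propyl chain in place of the 2-((isopropylcarbamoyl)amino)ethyl linker would be accepted.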